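A Phenyl Exchange on Compound 2

This account rests on a few compounds, and the source may have more. Where it says the series, first, only, none or still open, it means among the compounds named here.

Compound 1 (`COc1cccc(NC(=O)c2nnn(Cc3ccc(C(C)C)cc3)c2N)c1`) gives 14000 nM in a physicochemical assay for solubility, read by nephelometry, at pH 7.4 (on this read-out higher numbers stand for higher solubility and lower numbers for lower solubility), and compound 2 (`COc1cccc(NC(=O)c2nnn(Cc3ccccc3)c2N)c1`) gives 16000 nM on the same scale. Going by the values given here, these two values lie within the scatter of each other, which leaves compound 2 with no distinct place among the numbers so far.

Compound 3 (`COc1cccc(NC(=O)c2nnn(Cc3cc(C)on3)c2N)c1`) departs from compound 2 by a larger exchange (5-methyl-1,2-oxazol-3-yl in place of phenyl on a saturated chain carbon bound to an aromatic nitrogen), with 5-methyl-1,2-oxazol-3-yl in place of phenyl on a saturated chain carbon bound to an aromatic nitrogen. Among the compounds with values here, only one measured step bears on this, and only loosely: a 1.1-fold higher number from compound 1 to compound 2 (0.06 log units; within the scatter) is hydrogen in place of isopropyl on an aromatic carbon. Within the data shown here, that step keeps the phenyl, and no measured compound carries the entering group. The smallness of the step (a 1.1-fold higher number from compound 1 to compound 2 (0.06 log units; within the scatter)) is therefore weak guidance, but it offers no ground for expecting a large move in this assay. The expected step is a 1.1-fold higher number from compound 2 to compound 3 (0.05 log units; within the scatter) and no direction is expected beyond the scatter. Compound 3 is estimated at 18000 nM with a wide expected range (8000 nM to 40000 nM).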

Compound 3, solubility: 174000 nM
Compound 3: middle estimate off by 9.7-fold (0.99 log units), on the low side, outside the stated range (above it).
By their numbers in this assay, from the lowest: compounds 1 and 2 (each within the scatter of the next); then compound 3.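

In this assay the exchange of phenyl for 5-methyl-1,2-oxazol-3-yl on a saturated chain carbon bound to an aromatic nitrogen gives an 11-fold higher number from compound 2 to compound 3 (1.04 log units; beyond the scatter) and the exchange of 4-isopropylphenyl for the same group gives a 12-fold higher number from compound 1 to compound 3 (1.09 log units; beyond the scatter). This shows that the place is far from indifferent: the earlier step at the para-free level of the phenyl, a 1.1-fold higher number from compound 1 to compound 2 (0.06 log units; within the scatter), stayed within the scatter, whereas replacing the aromatic ring itself moves the number well beyond it, whichever of the two phenyl groups leaves. Nothing shown explains the size of this step, so it can be tied only to the exchange as a whole and not to any single feature of the entering group.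

The compounds shown leave open whether the methyl is needed, since 1,2-oxazol-3-yl without it does not appear among them, and whether a pyridyl group at this place would give a step of like size. They also leave open whether an amine or a carboxylic acid on the phenyl would move the number as far as this ring exchange does.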